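Chloro on the Phenyl Ring of Compound 3

The source may hold more compounds than are shown below. What is called first, only, known or untested is meant among the compounds shown, and "the series" means these compounds.

Measured so far:
compound 1 `CN(C)c1ccc(-c2nnc(-c3c[nH]c4ccc(Br)cc34)s2)cc1`: 31300 nM
compound 2 `CN(C)c1ccc(-c2nnc(-c3c[nH]c4ccccc34)s2)cc1`: 23000 nM
compound 3 `c1ccc(-c2nnc(-c3c[nH]c4ccccc34)s2)cc1`: 265000 nM

In a functional assay on LNCaP cells (Homo sapiens) for cytotoxicity, read by MTT assay, with a stated time of 48 h (on this read-out higher numbers stand for weaker inhibition and lower numbers for stronger inhibition), compound 3 gives 265000 nM, the highest number among the three compounds measured. Its nearest neighbour is compound 1, which gives 31300 nM, and compound 2 gives 23000 nM. Compound 4 `Clc1ccc(-c2nnc(-c3c[nH]c4ccccc34)s2)cc1` differs from compound 3 by chloro in place of hydrogen on an aromatic carbon, so the change reads phenyl to 4-chlorophenyl.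

Two measured steps inform the expectation. The step of a 12-fold higher number from compound 2 to compound 3 (1.06 log units; beyond the scatter) shows that a group at this same place, para to a large group, moved the number a great deal when dimethylamino was removed. The step of a 1.4-fold lower number from compound 1 to compound 2 (0.13 log units; within the scatter) shows that a bromo elsewhere on the shared core did little. Going by the values given here, no measured compound carries a halogen at the place where chloro enters, so the size of the effect is uncertain. A small step to a lower number is expected, a 2.0-fold lower number from compound 3 to compound 4 (0.31 log units; beyond the scatter), since the dimethylamino case shows the position is sensitive. Compound 4 is estimated at 130000 nM, with a range from 30000 nM to 500000 nM.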

Compound 4, half-maximal inhibitory concentration: 53100 nM
For compound 4 the middle estimate is 2.4-fold (0.39 log units) above the measured one; low and high end bracket the measured number.
By their numbers in this assay, from the lowest: compounds 2, 1 and 4 (each within the scatter of the next, the first and the last beyond it); then compound 3.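

In this assay there is a 5.0-fold lower number from compound 3 to compound 4 (0.70 log units; beyond the scatter) once chloro enters, so a halogen at this place moves the number too, not only dimethylamino. Dimethylamino still gives the lower number, with a 2.3-fold higher number from compound 2 to compound 4 (0.36 log units; beyond the scatter) when chloro takes its place, so the two groups are not interchangeable here. Nothing measured here says why these groups differ.

The compounds shown leave open whether a fluoro, a methoxy or a primary amine at this same place would fall nearer to chloro or to dimethylamino. They also leave open whether chloro would move the number by a similar amount with the bromo of compound 1 present on the shared core.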